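The source may report more compounds than this note shows. Statements on the series, on what has been measured and on what is new or still open speak of the compounds shown alone.

Among the compounds with values here, compound 3 `CC(=O)OC[C@H]1O[C@@H](Oc2ccc(-c3nnc(-c4ccc([N+](=O)[O-])cc4)o3)cc2)[C@H](OC(C)=O)[C@@H](OC(C)=O)[C@@H]1OC(C)=O` gives 58% in a functional assay on MDA-MB-231 cells (Homo sapiens) for inhibition, read by MTT assay, with a stated time of 24 h, tested at 100 uM (on this read-out higher numbers stand for more inhibition at the one concentration tested (going by the name of the read-out) and lower numbers for less inhibition), and stands highest of the three numbers so far; compound 1 `CCCCCc1nnc(-c2ccc(O[C@@H]3O[C@H](COC(C)=O)[C@@H](OC(C)=O)[C@H](OC(C)=O)[C@H]3OC(C)=O)cc2)o1` gives 21.5% and compound 2 `O=C(N/N=C/c1cccc([N+](=O)[O-])c1)c1ccc(O[C@@H]2O[C@H](CO)[C@@H](O)[C@H](O)[C@H]2O)cc1` gives 6.23%, both lying below it beyond the scatter. Compound 4 `CC(=O)OC[C@H]1O[C@@H](Oc2ccc(-c3nnc(C4CCCCC4)o3)cc2)[C@H](OC(C)=O)[C@@H](OC(C)=O)[C@@H]1OC(C)=O` has not yet been measured and differs from compound 3 in one place: cyclohexyl in place of 4-nitrophenyl on an aromatic carbon. Within the data shown here, one measured step bears on this change, a number 36.5 percentage points higher from compound 1 to compound 3 (beyond the scatter), which put 4-nitrophenyl in place of pentyl. The present step runs the other way, with cyclohexyl in place of 4-nitrophenyl, so a drop of comparable size is expected, bringing the number back toward that of compound 1. Compound 4 is therefore expected to give about 25% in this assay, between 10% and 45%, an expected step of a number 33 percentage points lower from compound 3 to compound 4 (beyond the scatter).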

Compound 4, a percentage reported as inhibition, at one concentration (the size of the read-out at that concentration, not a potency): 11.6%
The estimate for compound 4 lay 13.4 percentage points above the measured number, within the range that was stated.
By their numbers in this assay, from the lowest: compounds 2, 4 and 1 (each within the scatter of the next, the first and the last beyond it); then compound 3.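

In this assay cyclohexyl in place of 4-nitrophenyl gives a number 46.4 percentage points lower from compound 3 to compound 4 (beyond the scatter) and so shows that a six-membered carbon ring at this position does not by itself keep the high number of compound 3. Cyclohexyl in place of pentyl gives a number 9.9 percentage points lower from compound 1 to compound 4 (within the scatter) and so does not separate the ring from the chain. Nothing measured here explains these steps.

The compounds shown leave open whether the high number of compound 3 belongs to the aromatic ring or to its nitro group. A plain phenyl or an aminophenyl at this position would separate the two.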